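A Hydroxy Added to Compound 1

A few compounds are considered here, and "the series" means these few. Any claim that something is new, unique, unknown or untested is made for them only; others in the source may bear on it.

Compound 1 `COc1ccc(NC(=O)NCCNS(=O)(=O)c2ccc(-c3ccccc3OCc3ccccc3)s2)cc1`: > 50000 nM (a limit)
Compound 2 `O=S(=O)(NCCNC(=S)Nc1cccc(Cl)c1)c1ccc(-c2ccccc2OCc2ccccc2)s1`: > 50000 nM (a limit)
Compound 3 `Cc1cc(C)cc(NC(=O)NCCNS(=O)(=O)c2ccc(-c3ccccc3OCc3ccccc3)s2)c1`: 2200 nM

In a functional assay on HL-60 cells (Homo sapiens) for inhibition, read by CCK-8 assay, with a stated time of 48 h (on this read-out higher numbers stand for weaker inhibition and lower numbers for stronger inhibition), compound 1 gives > 50000 nM, which is a limit and not a number. It stands at the limit of > 50000 nM in this assay, at which 2 of the 3 values shown sit.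

Compound 4 `COc1ccc(NC(=O)NCCNS(=O)(=O)c2ccc(-c3ccccc3OCc3cccc(O)c3)s2)cc1` differs from compound 1 in one place: hydroxy in place of hydrogen on an aromatic carbon. In words, benzyl becomes 3-hydroxybenzyl.

Among the compounds with values here, no measured step touches this group. The step that the two limits leave unreadable from compound 1 to compound 2 cannot be read. The step of an at least 22-fold lower number from compound 1 to compound 3 (1.35 log units; beyond the scatter) is large, and so is the step of an at least 22-fold lower number from compound 2 to compound 3 (1.35 log units; beyond the scatter), but both come from changes elsewhere in the molecule. They show that this assay can respond strongly within this series, but they do not size the new change. Only a modest shift towards a lower number is therefore expected, and compound 4 may well remain at the limit.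

The expected change is an at least 1.4-fold lower number from compound 1 to compound 4 (0.15 log units; that floor lies within the scatter).

Compound 4 is estimated at 35000 nM, with an expected range of 5000 nM to 100000 nM.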

Compound 4, half-maximal inhibitory concentration: > 20000 nM
Compound 4 gave a limit, no number; the forecaster's own chance of this, stated with the estimate: 55%; the middle value lies beyond the limit too.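

In this assay compound 1 and compound 4 each give only a limit, so the step between them, hydroxy in place of hydrogen, cannot be read. The compounds shown leave open whether benzyl to 3-hydroxybenzyl shifts the read-out at all, and in which direction.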